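This account rests on a few compounds, and the source may have more. Where it says the series, first, only, none or still open, it means among the compounds named here.

Measured so far:
Compound 1 `O=c1c2ccccc2[se]n1-c1nc(SCc2ccc(F)cc2)n[nH]1`: 46100 nM
Compound 2 `O=c1c2ccccc2[se]n1-c1nc(SCc2ccc(Cl)cc2)n[nH]1`: 33900 nM

Both numbers come from a functional assay on SMMC-7721 cells (Homo sapiens) for antiproliferative activity, read by CCK-8 assay, with a stated time of 48 h; a higher number here means a weaker inhibitor, a lower number a stronger inhibitor. Compound 2 and compound 1 stand close together on this scale: a 1.4-fold lower number from compound 1 to compound 2 (0.13 log units; within the scatter), so the two cannot be told apart on these data, and neither can be called the more or less potent of the pair.

Compound 3 `CCCSc1n[nH]c(-n2[se]c3ccccc3c2=O)n1` is the next step from compound 2. The change is ethyl in place of 4-chlorophenyl on a saturated chain carbon bound to a sulfur. For the measured compounds named here, no measured step resembles this one. Going by the values given here, the only step recorded, the halogen exchange from compound 1 to compound 2, leaves the aryl group in place and says nothing about what happens when that group is removed altogether and a short chain is left on the sulfur. The expectation for compound 3 in this assay therefore rests on the structural change alone, with a wide range.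

Compound 3 is expected to give a somewhat higher number than compound 2, by a 1.9-fold higher number from compound 2 to compound 3 (0.28 log units; within the scatter), though a result within the scatter would not be surprising. The estimate for compound 3 is 65000 nM, between 25000 nM and 170000 nM.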

Compound 3, half-maximal inhibitory concentration: 6020 nM
The estimate for compound 3 lay 11-fold (1.03 log units) above the measured number; measured number outside the range, below it.
By their numbers in this assay, from the lowest: compound 3; then compounds 2 and 1 (each within the scatter of the next).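

In this assay the group on the sulfur proves to matter more than the halogen it carries: ethyl in place of 4-chlorophenyl on a saturated chain carbon bound to a sulfur gives a 5.6-fold lower number from compound 2 to compound 3 (0.75 log units; beyond the scatter) and ethyl in place of 4-fluorophenyl at the same place gives a 7.7-fold lower number from compound 1 to compound 3 (0.88 log units; beyond the scatter) while both steps lie beyond the scatter, which the exchange of fluoro for chloro did not reach. The aromatic ring is therefore not needed for activity on this scale, as the short propyl chain of compound 3 outperforms both the 4-chlorobenzyl group of compound 2 and the 4-fluorobenzyl group of compound 1. No measurement available here accounts for this gain.

With propyl as the only saturated chain among these compounds, it remains open whether the gain depends on chain length, and whether a methyl group, a butyl group or a longer chain on the sulfur would give a lower or a higher number. As far as these compounds go, it is also open whether an unsubstituted benzyl group would stand with the halogenated pair, and how an amine or a carboxylic acid carried on the propyl chain would read in this assay.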